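The source may report more compounds than this note shows. Statements on the series, on what has been measured and on what is new or still open speak of the compounds shown alone.

In a functional assay on ECa-109 cells (Homo sapiens) for inhibition, read by MTT assay, with a stated time of 72 h (a lower number here means a stronger inhibitor, a higher number a weaker inhibitor), compound 3 `N#Cc1c(Nc2cccc(Cl)c2)nc(SCc2cn(Cc3ccccc3Cl)nn2)nc1-c1ccccc1` gives 24400 nM. Compound 2 `N#Cc1c(Nc2ccccc2Cl)nc(SCc2cn(Cc3ccccc3Cl)nn2)nc1-c1ccccc1` carries a 2-chlorophenyl where compound 3 carries a 3-chlorophenyl, and in this assay compound 2 gives 28500 nM. The step of a 1.2-fold lower number from compound 2 to compound 3 (0.07 log units; within the scatter) shows that swapping one chlorophenyl for the other left the read-out essentially unchanged. Compound 1 `C#CCSc1nc(Nc2ccc(Cl)cc2)c(C#N)c(-c2ccccc2)n1` differs from both in more than one place, and in this assay compound 1 reaches only a limit, > 128000 nM (the limit of > 128000 nM in this assay, at which 1 of the 3 values shown sits). Among the numbers shown, compound 3 and compound 2 lie within the scatter of each other, and the remaining entry is a limit, so compound 3 cannot be set apart from compound 2.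

Compound 4 `N#Cc1c(Nc2cccc([N+](=O)[O-])c2)nc(SCc2cn(Cc3ccccc3Cl)nn2)nc1-c1ccccc1` differs from compound 3 by nitro in place of chloro on an aromatic carbon. Going by the values given here, no measured step replaces chloro with nitro; the only measured step, a 1.2-fold lower number from compound 2 to compound 3 (0.07 log units; within the scatter), concerns the same aromatic ring and stayed within the scatter. There is therefore no measured basis for expecting a large move, and the expectation for compound 4 is a step of a 1.0-fold lower number from compound 3 to compound 4 (0.01 log units; within the scatter), inside the scatter. On that basis compound 4 is estimated to give 24000 nM in this assay, with a range from 8000 nM to 72000 nM.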

Compound 4, half-maximal inhibitory concentration: > 64000 nM
Compound 4 was reported as a limit; the forecaster's own chance of this, stated with the estimate: 15%; at least 2.6-fold (0.42 log units) between middle value and limit.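

In this assay, this aromatic ring had so far shown no clear response: 3-chlorophenyl in place of 2-chlorophenyl stayed within the scatter. Nitro in place of chloro is the first change at this ring that moves the read-out beyond the scatter, toward weaker inhibition, with an at least 2.6-fold higher number from compound 3 to compound 4 (0.41 log units; beyond the scatter), and the comparison with the other chlorophenyl compound points the same way, with an at least 2.2-fold higher number from compound 2 to compound 4 (0.35 log units; beyond the scatter). Compound 4 gives only a limit, so each step has a smallest size but no measured full size: the limit of > 64000 nM in this assay, at which 1 of the 4 values shown sits.

Only chloro and nitro are shown on this ring at the place named by 3-chlorophenyl and 3-nitrophenyl, so it remains open whether an amine, a methoxy group or a carboxylic acid there would stay close to compound 3 or shift the read-out as nitro does. As far as these compounds go, it is also open whether nitro in place of chloro would give a step of similar size if another part of the shared core carried a different group.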